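A few compounds are considered here, and "the series" means these few. Any claim that something is new, unique, unknown or untested is made for them only; others in the source may bear on it.

Compound 1 `CCCCCCCCNC(=O)[C@@H](NC(=O)c1nccc2ccccc12)[C@@H](C)O` carries an octyl chain on its amide nitrogen. In a functional assay on MCF7 cells (Homo sapiens) for cytotoxicity, read by MTT assay, with a stated time of 48 h (on this read-out higher numbers stand for weaker inhibition and lower numbers for stronger inhibition), compound 1 gives 63200 nM, the highest of the three numbers measured. Compound 2 `CCCCCCCCCCCCNC(=O)[C@@H](NC(=O)c1cc2ccccc2[nH]1)[C@@H](C)O`, which has a dodecyl chain and a different core, gives 12300 nM in this assay. For the measured compounds named here, compound 3 `CCCCCCCCCCCCNC(=O)[C@@H](NC(=O)c1cc2ccccc2n1C)[C@@H](C)O` gives 31300 nM in this assay, and the only single-point step measured, a 2.5-fold higher number from compound 2 to compound 3 (0.41 log units; beyond the scatter), concerns the aromatic nitrogen rather than the chain.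

Compound 4 `CCCCCCCCCCCCCCCCCCNC(=O)[C@@H](NC(=O)c1nccc2ccccc12)[C@@H](C)O` keeps the core of compound 1 and differs from it by one change: decyl in place of hydrogen on a saturated chain carbon, eight bonds along the chain from an amide-type nitrogen, so the octyl chain becomes an octadecyl chain. Going by the values given here, no measured step isolates a change in chain length. Among the compounds with values here, compound 1 and compound 2 differ in both chain and core, so their values show only that the longer-chain compound gave the lower number, without telling which change caused it. The step at the aromatic nitrogen, from compound 2 to compound 3, does not bear on a chain extension.

Within the data shown here, with no step of the same kind to lean on, compound 4 is expected to give 40000 nM in this assay, within 12000 nM to 130000 nM, a step of a 1.6-fold lower number from compound 1 to compound 4 (0.20 log units; within the scatter) that is estimated and not established.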

Compound 4, half-maximal inhibitory concentration: 30800 nM
Estimate against measurement, compound 4: 1.3-fold (0.11 log units) above, and the stated range covers the measured number.
By their numbers in this assay, from the lowest: compound 2; then compounds 4 and 3 (each within the scatter of the next); then compound 1.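

Decyl in place of hydrogen on a saturated chain carbon, eight bonds along the chain from an amide-type nitrogen, gives the first reading of chain length on its own: with the core of compound 1 held fixed, this assay shows a 2.1-fold lower number from compound 1 to compound 4 (0.31 log units; beyond the scatter). The step is modest but lies beyond the scatter, so on this core the octadecyl chain and the octyl chain can be told apart, and this large all-carbon extension at this position goes with a lower number rather than a higher one. Nothing given here speaks to the cause of this step.

A single step joins only the two ends of this comparison, so the compounds shown leave open whether the number falls steadily with chain length or whether an intermediate chain, such as hexadecyl, on the same core would give a lower number than either. They also leave open what a chain ending in an amine or a carboxylic acid would give at this position.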